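Exchanging the fluoro of compound 3

This account rests on a few compounds, and the source may have more. Where it says the series, first, only, none or still open, it means among the compounds named here.

In a functional assay on DU-145 cells (Homo sapiens) for cytotoxicity, read by trypan blue exclusion, with a stated time of 96 h (on this read-out lower numbers stand for stronger inhibition and higher numbers for weaker inhibition), compound 1 `COc1cc(OC)c(/C=C/S(=O)(=O)Nc2ccc(F)c(N)c2)c(OC)c1` gives 10000 nM. Compound 2 `COc1ccc(/C=C/S(=O)(=O)Nc2ccc(F)cc2)cc1` also gives 10000 nM. Compound 3 `COc1cc(OC)c(/C=C/S(=O)(=O)Nc2ccc(OC)c(F)c2)c(OC)c1` gives 200 nM, the lowest of the three numbers and beyond the scatter of both others.

Compound 4 `COC(=O)C(C)(C)Nc1cc(NS(=O)(=O)/C=C/c2c(OC)cc(OC)cc2OC)ccc1OC` differs from compound 3 at one place: (1-(methoxycarbonyl)-1-methylethyl)amino in place of fluoro on an aromatic carbon. In words, (1-(methoxycarbonyl)-1-methylethyl)amino stands in place of fluoro on an aromatic carbon, ortho to a methoxy group.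

Within the data shown here, only one measured step bears on this change. It is a 50-fold lower number from compound 1 to compound 3 (1.70 log units; beyond the scatter), a large step, with 3-fluoro-4-methoxyphenyl in place of 3-amino-4-fluorophenyl on a sulfonamide nitrogen. That step shows that the number can move strongly with the group on this nitrogen, but it alters more than the fluoro and gives no direction for the present exchange. Among the measured compounds shown here, no measured compound carries the entering group, so the data do not show which way the number will go. The estimated change is a 1.3-fold higher number from compound 3 to compound 4 (0.10 log units; within the scatter), which means no expected step beyond the scatter, with wide uncertainty on either side. For compound 4 the expected value in this assay is 250 nM, with an estimated range of 25 nM to 2500 nM.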

Compound 4, half-maximal inhibitory concentration: 200 nM
For compound 4 the middle estimate is 1.3-fold (0.10 log units) above the measured one; the measured number falls inside the stated range.
By their numbers in this assay, from the lowest: compounds 3 and 4 (each within the scatter of the next); then compounds 1 and 2 (each within the scatter of the next).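

Working notes on the fluoro position. In this assay the exchange gives no change at the digits printed from compound 3 to compound 4 (within the scatter), so fluoro, with 1 heavy atom, and (1-(methoxycarbonyl)-1-methylethyl)amino, with 8 heavy atoms, cannot be told apart by this read-out at this place on the ring. The earlier step altered more than the fluoro, whereas this pair isolates the aromatic carbon ortho to a methoxy group and shows, for this one exchange, that a much larger entering group need not cost anything in the number. The entering group also adds 1 hydrogen-bond donor, 3 hydrogen-bond acceptors and a double bond outside aromatic rings, and none of these additions brings a step beyond the scatter in this pair. No evidence on hand accounts for this outcome.

The compounds shown leave open whether a carboxylic acid in place of the methoxycarbonyl part of the entering group would hold the number at this level. They also leave open whether a hydroxyl or a longer alkyl chain on this carbon would do the same, so the limits of this position remain undefined.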